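The source may hold more compounds than are shown below. What is called first, only, known or untested is meant among the compounds shown, and "the series" means these compounds.

Measured so far:
- compound 1, `Cc1ccc(O)c(CNc2ccc(C3CCCCC3)cc2)c1`: "not active" (no number reported)
- compound 2, `Oc1cc(-c2ccccc2)ccc1CNc1ccc(C2CCCCC2)cc1`: "not active" (no number reported)
- compound 3, `Oc1ccccc1CNc1ccc(-c2ccc(F)cc2)cc1`: 3860 nM

The series was followed in a functional assay on Jurkat cells (Homo sapiens) for activation, with a stated time of 24 h; a lower number here means that less compound is needed, a higher number that more compound is needed for the effect. Compound 1 and compound 2 each gave no number, only the note that no activity was seen. Within the data shown here, compound 3 is thus the one member with a measured value, so it stands as the only numerical point of reference, and no step between measured compounds can be computed.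

Compound 4, `Oc1ccc(-c2ccc(NCc3ccccc3O)cc2)cc1`, is the next entry. It differs from compound 3 in a single place: hydroxy in place of fluoro on an aromatic carbon. Among the measured compounds shown here, neither compound 1 nor compound 2 carries this change, so the data give no precedent for its effect.

With one reference value only, the expectation for compound 4 is a small step, within the scatter of repeated measurements, with no clear direction. The estimate for compound 4 in this assay is 3000 nM, with a range from 800 nM to 12000 nM. This expected step from compound 3 reads a 1.3-fold lower number from compound 3 to compound 4 (0.11 log units; within the scatter).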

Compound 4, half-maximal effective concentration: "not active" (no number reported)
Compound 4 has no reported number here, and the estimate cannot be compared.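

In this assay compound 3 gives 3860 nM and compound 4 gives "not active" (no number reported) so no step can be read between compound 3 and compound 4. No supporting data bear on this result. The compounds shown leave open what the change from 4-fluorophenyl to 4-hydroxyphenyl does on a numerical scale.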